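Replacing the sulfonyl aryl group of compound 2

The source may report more compounds than this note shows. Statements on the series, on what has been measured and on what is new or still open speak of the compounds shown alone.

In an ADME assay on HEK293 cells (Homo sapiens) for antiproliferative activity, read by MTT assay, with a stated time of 48 h (on this read-out lower numbers stand for stronger inhibition and higher numbers for weaker inhibition), compound 1 (`O=C(/C=C/c1cn(S(=O)(=O)c2ccc([N+](=O)[O-])cc2)c2ccccc12)c1ccncc1`) gives > 150000 nM, which is a limit of the assay and not a number. Compound 2 (`Cc1ccc(S(=O)(=O)n2cc(/C=C/C(=O)c3ccncc3)c3ccccc32)cc1`) also has only a limit, > 150000 nM, so its standing cannot be read more closely. Both values shown sit at one ceiling: the limit of > 150000 nM in this assay, at which 2 of the 2 values shown sit.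

Compound 3 (`O=C(/C=C/c1cn(S(=O)(=O)c2cccc([N+](=O)[O-])c2)c2ccccc12)c1ccncc1`) differs from compound 2 on a sulfonyl sulfur: 3-nitrophenyl in place of 4-methylphenyl on a sulfonyl sulfur. In short, 3-nitrophenyl takes the place of 4-methylphenyl.

Among the compounds with values here, the only measured step that bears on this change is a step that the two limits leave unreadable from compound 1 to compound 2, with methyl in place of nitro on an aromatic carbon. It offers no size to carry over, and no direction either. No step beyond the scatter is therefore expected, and another limit is the likeliest report.

The expected change is a step that the limit leaves unreadable from compound 2 to compound 3. For compound 3 the estimated value is 200000 nM, with an expected range of 90000 nM to 400000 nM.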

Compound 3, half-maximal inhibitory concentration: > 150000 nM
Compound 3 gave a limit, no number; the forecaster's own chance of this, stated with the estimate: 85%; the middle value is on the limit's open side.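

Compound 3 gives > 150000 nM, which is a limit of the assay and not a number. No new step can be read between compound 3 and compound 1 or compound 2, because all three rest on one ceiling: the limit of > 150000 nM in this assay, at which 3 of the 3 values shown sit.

The compounds shown leave open whether 3-nitrophenyl, 4-nitrophenyl and 4-methylphenyl differ at all in this assay.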